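A few compounds are considered here, and "the series" means these few. Any claim that something is new, unique, unknown or untested is made for them only; others in the source may bear on it.

Measured so far in a functional assay on COLO 205 cells (Homo sapiens) for cytotoxicity, read by MTT assay, with a stated time of 72 h; a lower number here means a stronger inhibitor, a higher number a weaker inhibitor:
- compound 1 `COc1ccc(C(=O)c2cc(OC)c(OC)c(OC)c2)cc1NC(=O)/C=C/c1cc(OC)c(OC)c(OC)c1` gives 5200 nM
- compound 2 `COc1ccc(C(=O)c2cc(OC)c(OC)c(OC)c2)cc1NC(=O)/C=C/c1ccc(F)cc1` gives 3400 nM
- compound 3 `COc1cc(/C=C/C(=O)Nc2cc(C(=O)c3cc(OC)c(OC)c(OC)c3)ccc2OC)ccc1F` gives 11800 nM

Compound 3 stands highest of the three numbers in this assay: a 2.3-fold higher number from compound 1 to compound 3 (0.36 log units; beyond the scatter) and a 3.5-fold higher number from compound 2 to compound 3 (0.54 log units; beyond the scatter) are both modest and beyond the scatter, while a 1.5-fold lower number from compound 1 to compound 2 (0.18 log units; within the scatter) stays within it. Compound 4 `COc1ccc(C(=O)c2cc(OC)c(OC)c(OC)c2)cc1NC(=O)/C=C/c1ccc([N+](=O)[O-])cc1` differs from compound 3 by 4-nitrophenyl in place of 4-fluoro-3-methoxyphenyl on a double-bonded chain carbon bound to a double-bonded chain carbon. Among the compounds with values here, no measured step carries a nitrophenyl group, so the only guide is that the ring lacking a methoxy, compound 2, sits below compound 3 in this assay, and that the swap of one whole aryl group for another, as in a 1.5-fold lower number from compound 1 to compound 2 (0.18 log units; within the scatter), moved little. A modest downward step, a 2.6-fold lower number from compound 3 to compound 4 (0.42 log units; beyond the scatter), is therefore expected, with wide uncertainty. Compound 4 is expected at 4500 nM, within 1500 nM to 13000 nM.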

Compound 4, half-maximal inhibitory concentration: 11400 nM
The estimate for compound 4 lay 2.5-fold (0.40 log units) below the measured number, and the stated range covers the measured number.
By their numbers in this assay, from the lowest: compounds 2 and 1 (each within the scatter of the next); then compounds 4 and 3 (each within the scatter of the next).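

In this assay the 4-nitrophenyl and 4-fluoro-3-methoxyphenyl groups at this position cannot be told apart, with a 1.0-fold lower number from compound 3 to compound 4 (0.01 log units; within the scatter) as the step between them. Both numbers stand apart from the other two: nitro in place of fluoro on an aromatic carbon gives a 3.4-fold higher number from compound 2 to compound 4 (0.53 log units; beyond the scatter) and 4-nitrophenyl in place of 3,4,5-trimethoxyphenyl gives a 2.2-fold higher number from compound 1 to compound 4 (0.34 log units; beyond the scatter) in the same assay. No measured evidence bears on this result.

On these data alone, an amine or a carboxylic acid in place of the nitro group remains open. So does whether any aryl group here can move the number below that of compound 2.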